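Removing a Hydroxy Group from a Polyene Amide

This account rests on a few compounds, and the source may have more. Where it says the series, first, only, none or still open, it means among the compounds named here.

Compound 1 `C/C=C/C=C/C=C\CC/C=C/C=C/C(=O)NC(C)(C)O` is a long unsaturated chain that ends in an amide. In a functional assay on cells (Platelet, Oryctolagus cuniculus) for inhibition, read by turbidimetry, with a stated time of 3 min, tested at 100 ug/mL (on this read-out lower numbers stand for a stronger effect and higher numbers for a weaker effect at the one concentration tested), compound 1 gives 0%. Its nearest relative, compound 2 `CC/C=C/C/C=C\CC/C=C/C=C/C(=O)NCC(C)(C)O`, in this assay gives 0%; the two values are level at the digits shown and lie within the usual scatter of this read-out, so no order between them can be stated. Compound 3 `C/C=C/C=C/C=C\CC/C=C/C=C/C(=O)NC(C)C` has not yet been tested. It differs from compound 1 in a single place: hydrogen in place of hydroxy on a saturated chain carbon bound to an amide-type nitrogen and two saturated chain carbons. Cut one bond further out, the same difference reads 1-hydroxy-1-methylethyl to isopropyl. Among the measured compounds shown here, no measured pair shows what such a change does here, so the only support for an expectation is the measured values themselves. With both measured compounds at the bottom of the read-out, the step of a number 5 percentage points higher from compound 1 to compound 3 (within the scatter) is expected to be small or none beyond the scatter. Compound 3 is therefore estimated at 5%, with a range from 0% to 25%.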

Compound 3, a percentage reported as activity, at one concentration (the size of the read-out at that concentration, not a potency): 0%
Estimate against measurement, compound 3: 5 percentage points above; low and high end bracket the measured number.
By their numbers in this assay, from the lowest: compounds 1, 2 and 3 (each within the scatter of the next).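

Among the compounds shown here, the swap of hydroxy for hydrogen on this saturated chain carbon, read in this assay, gives no change at the digits printed from compound 1 to compound 3 (within the scatter) and is the first direct reading of any change at this place. The 1-hydroxy-1-methylethyl group and the isopropyl group therefore cannot be told apart on this read-out, so the hydroxy group is not needed to keep the value at the bottom of the scale. No other data bear on why the swap leaves the number as it is.

Both compounds sit at the bottom of the read-out, so a further gain in effect from this swap could not show up here. As far as these compounds go, whether an amine, a carboxylic acid or a longer chain at this same carbon would move the value away from the bottom remains open.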